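This account rests on a few compounds, and the source may have more. Where it says the series, first, only, none or still open, it means among the compounds named here.

Compound 1, `Cc1cc(CCOc2ccc(-c3c(C)nc(C)c([C@H](OC(C)(C)C)C(=O)O)c3N3CCC(C)(C)CC3)cc2)ccc1F`, gives in an ADME assay on microsomes from liver (Homo sapiens) for metabolic stability, read by LC-MS, tested at 0.5 uM (on this read-out lower numbers stand for a shorter-lived compound and higher numbers for a longer-lived compound), a limit of > 2 h.
Compound 2, `Cc1nc(C)c([C@H](OC(C)(C)C)C(=O)O)c(N2CCC(C)(C)CC2)c1-c1ccc(OC2COCC2c2ccc(F)cc2)cc1`, gives in this assay 0.783 h.

Compound 2 stands as the only number shown in this assay; the other value is a limit, namely (the limit of > 2 h in this assay, at which 1 of the 2 values shown sits). Compound 3, `Cc1nc(CCOc2ccc(-c3c(C)nc(C)c([C@H](OC(C)(C)C)C(=O)O)c3N3CCC(C)(C)CC3)cc2)cs1`, differs from compound 2 in one place: 2-(2-methyl-1,3-thiazol-4-yl)ethyl in place of 4-(4-fluorophenyl)oxolan-3-yl on an oxygen on an aromatic ring. Among the measured compounds shown here, the one measured step that bears on this change is an at least 2.5-fold lower number from compound 1 to compound 2 (0.40 log units; beyond the scatter), in which an ethyl-linked aromatic ring gave way to the oxolane group. The change from compound 2 to compound 3 runs the other way, back to an ethyl-linked aromatic ring, though the ring itself differs from that of compound 1. A higher number is therefore expected, and the step of a 1.9-fold higher number from compound 2 to compound 3 (0.28 log units; within the scatter) is estimated as a modest rise. Compound 3 is expected to give about 1.5 h, in a range from 0.7 h to 3.5 h.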

Compound 3, half-life: 0.683 h
For compound 3 the middle estimate is 2.2-fold (0.34 log units) above the measured one, and the stated range ends above it.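

Replacing only the ring at the end of the ethyl chain gives an at least 2.9-fold lower number from compound 1 to compound 3 (0.46 log units; beyond the scatter) in this assay, so at this position the ethyl chain alone does not preserve the longer half-life of compound 1, and the ring it carries matters. The other step is a 1.1-fold lower number from compound 2 to compound 3 (0.06 log units; within the scatter), so the 2-(2-methyl-1,3-thiazol-4-yl)ethyl and 4-(4-fluorophenyl)oxolan-3-yl groups cannot be told apart here, although their rings differ. The figure for compound 1 is a limit, which makes the first step a bound and not an exact size: the limit of > 2 h in this assay, at which 1 of the 3 values shown sits.

On these data alone, it remains open whether a 4-fluorophenyl, plain phenyl or pyridine ring on the same ethyl chain would match compound 1 or compound 3. As far as these compounds go, how far compound 1 lies past its limit also remains open.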